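Opening the piperazine amide of compound 3

The compounds below may be only part of what the source reports. "The series", "measured", "known", "first", "only" and "open" are said of these compounds alone.

Measured in an ADME assay on the whole organism (Rattus norvegicus) for pharmacokinetics, at a dose of 2 mg/kg by the intravenous route; on this read-out lower numbers stand for slow clearance and higher numbers for fast clearance:
- compound 1 `CCc1cccc(CC)c1N1CCn2cc(-c3nc(Nc4ccc(N5CCC(N6CCN(C)CC6)CC5)cc4OC)nc4[nH]ccc34)cc2C1=O`: 52 mL/min/kg
- compound 2 `CCc1cccc(CC)c1N1CCn2cc(-c3nc(Nc4ccc(N5CCN(CC(=O)N(C)C)CC5)cc4OC)nc4[nH]ccc34)cc2C1=O`: 23 mL/min/kg
- compound 3 `CCc1cccc(CC)c1N1CCn2cc(-c3nc(Nc4ccc(N5CCC(C(=O)N6CCN(C)CC6)CC5)cc4OC)nc4[nH]ccc34)cc2C1=O`: 1.7 mL/min/kg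

Compound 3 has the lowest number of the three, and both other compounds lie beyond the scatter from it. Compound 4 `CCc1cccc(CC)c1N1CCn2cc(-c3nc(Nc4ccc(N5CCC(C(=O)N(C)CCN(C)C)CC5)cc4OC)nc4[nH]ccc34)cc2C1=O` differs from it on a carbonyl carbon, where (2-(dimethylamino)ethyl)(methyl)amino stands in place of 4-methylpiperazin-1-yl: (2-(dimethylamino)ethyl)(methyl)amino in place of 4-methylpiperazin-1-yl on a carbonyl carbon. The entering group has no ring.

Among the compounds with values here, only one measured step bears on this change, and only in part. The large step of a 31-fold lower number from compound 1 to compound 3 (1.49 log units; beyond the scatter) brought in the carbonyl, which compound 4 keeps. Within the data shown here, no measured step changes the group on that carbonyl, so the size of the new step is poorly constrained. Compound 4 is expected to keep much of the drop seen in a 31-fold lower number from compound 1 to compound 3 (1.49 log units; beyond the scatter), while compound 3 at 1.7 mL/min/kg leaves more room to rise than to fall. The expected change is a moderate rise, an estimated 4.1-fold higher number from compound 3 to compound 4 (0.61 log units; beyond the scatter). The estimate for compound 4 is 7 mL/min/kg, with an expected range from 2 mL/min/kg to 24 mL/min/kg.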

Compound 4, clearance: 27 mL/min/kg
Compound 4: middle estimate off by 3.9-fold (0.59 log units), on the low side; measured number above the stated range.
By their numbers in this assay, from the lowest: compound 3; then compounds 2, 4 and 1 (each within the scatter of the next, the first and the last beyond it).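

In this assay, the low number of compound 3 turns out to depend on the group on the carbonyl, and not on the carbonyl alone: the two groups match in every computed count and differ in the ring, yet opening it gives a 16-fold higher number from compound 3 to compound 4 (1.20 log units; beyond the scatter). The carbamoyl chain also leaves compound 4 within the scatter of its amine counterpart, as a 1.9-fold lower number from compound 1 to compound 4 (0.28 log units; within the scatter) shows, so keeping the carbonyl did not by itself preserve the earlier drop. Nothing measured here explains why opening the ring has this effect.

As far as these compounds go, it remains open whether another ring on the same carbonyl, such as morpholin-4-yl or a piperidin-1-yl bearing a dimethylamino group, would stay close to compound 3 at 1.7 mL/min/kg. A longer chain ending in the same dimethylamino group, or an amide that keeps the amide hydrogen in place of the methyl, is equally untested among the compounds shown.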